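The source may report more compounds than this note shows. Statements on the series, on what has been measured and on what is new or still open speak of the compounds shown alone.

Series notes. Compound 1 `O=C(O)c1cccc(-c2cnc(Nc3ccc(F)cc3F)o2)c1` gives 0.565 h in an ADME assay on microsomes from liver (Mus musculus) for metabolic stability, read by LC-MS, using NADPH; on this read-out higher numbers stand for a longer-lived compound and lower numbers for a shorter-lived compound. Compound 2 `COC(=O)c1cccc(-c2cnc(Nc3ccc(F)cc3)o2)c1` gives 0.0183 h in this assay, and compound 3 `CNC(=O)c1cccc(-c2cnc(Nc3ccc(F)cc3)o2)c1` gives 0.025 h in this assay; compound 3 thus stands second highest of the three numbers, closest to compound 2 and well beneath compound 1. Going by the values given here, the only single-point step measured, a 1.4-fold higher number from compound 2 to compound 3 (0.14 log units; within the scatter), concerns an exchange on the carbonyl carbon and does not cover what is done next. Compound 4 `Cc1noc(-c2cccc(-c3cnc(Nc4ccc(F)cc4)o3)c2)n1` carries 3-methyl-1,2,4-oxadiazol-5-yl in place of methylcarbamoyl on an aromatic carbon. Among the compounds with values here, no measured step bears directly on this exchange, so the size of the move in this assay is open; a small rise is expected, not clearly beyond the scatter. Compound 4 is therefore expected to give 0.05 h, between 0.015 h and 0.2 h. The expected step is a 2.0-fold higher number from compound 3 to compound 4 (0.30 log units; within the scatter).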

Compound 4, half-life: 0.383 h
Compound 4: the middle estimate sits 7.7-fold (0.88 log units) below what was measured; the measured number lies above the stated range.
By their numbers in this assay, from the lowest: compounds 2 and 3 (each within the scatter of the next); then compounds 4 and 1 (each within the scatter of the next).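

At this place, on an aromatic carbon meta to a large group, the half-life in this assay responds strongly to the group present: 3-methyl-1,2,4-oxadiazol-5-yl in place of methylcarbamoyl gives a 15-fold higher number from compound 3 to compound 4 (1.19 log units; beyond the scatter) and in place of methoxycarbonyl gives a 21-fold higher number from compound 2 to compound 4 (1.32 log units; beyond the scatter). The exchange on the carbonyl carbon stayed within the scatter, whereas replacing the whole group with the ring does not. Nothing available explains the size of this rise.

Open, going by these compounds, is whether the step depends on the methyl of the ring, which the oxadiazole without a methyl group would address. Also open, on these data alone, is whether a nitrile or a tetrazole at this place would behave alike.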